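The source may report more compounds than this note shows. Statements on the series, on what has been measured and on what is new or still open speak of the compounds shown alone.

Compound 1 `O=S(=O)(NCCCNc1nccc(-c2c(-c3cccc(F)c3)nc3sccn23)n1)c1ccc(Cl)cc1`: 8450 nM
Compound 2 `Cc1ccc(S(=O)(=O)NCCNc2nccc(-c3c(-c4cccc(F)c4)nc4sccn34)n2)cc1`: > 20000 nM
Compound 3 `O=S(=O)(NCCNc1nccc(-c2c(-c3cccc(F)c3)nc3sccn23)n1)c1cccc(F)c1`: 18300 nM

In a functional assay on SK-MEL-28 cells (Homo sapiens) for cytotoxicity, read by MTT assay (a lower number here means a stronger inhibitor, a higher number a weaker inhibitor), compound 3 gives 18300 nM, the higher of the two numbers reported; the nearest number is that of compound 1, and the step of a 2.2-fold higher number from compound 1 to compound 3 (0.34 log units; beyond the scatter) lies beyond the scatter. For compound 2 the value > 20000 nM is a limit of the assay (the limit of > 20000 nM in this assay, at which 1 of the 3 values shown sits). The aryl swap on the sulfonyl, an at least 1.0-fold lower number from compound 2 to compound 3 (0.03 log units; that floor lies within the scatter), shows no difference beyond the scatter.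

Compound 4 `Cc1ccc(C(=O)NCCNc2nccc(-c3c(-c4cccc(F)c4)nc4sccn34)n2)cc1` differs from compound 3 by (4-methylphenyl)carbonyl in place of (3-fluorophenyl)sulfonyl on an amine nitrogen. Among the measured compounds shown here, no measured step exchanges sulfonyl for carbonyl, so only the flat aryl comparison and the generally weak range bear on it. The expected step of a 1.1-fold higher number from compound 3 to compound 4 (0.04 log units; within the scatter) is therefore none beyond the scatter. Compound 4 is estimated at 20000 nM, between 7000 nM and 60000 nM.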

Compound 4, half-maximal inhibitory concentration: 18800 nM
Beside the measured number, compound 4's estimate is 1.1-fold (0.03 log units) above it; low and high end bracket the measured number.
By their numbers in this assay, from the lowest: compound 1; then compounds 3 and 4 (each within the scatter of the next). At a limit, above all of these: compound 2.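

In this assay, (4-methylphenyl)carbonyl in place of (3-fluorophenyl)sulfonyl on an amine nitrogen gives a 1.0-fold higher number from compound 3 to compound 4 (0.01 log units; within the scatter), which is no difference beyond the scatter. The carbonyl compound also keeps the modest gap to the more active compound 1 (a 2.2-fold higher number from compound 1 to compound 4 (0.35 log units; beyond the scatter)). Going by these compounds, whether a longer chain carrying the (4-methylphenyl)carbonyl, or an amine or carboxylic acid on its ring, would move the number beyond the scatter stays open. Compound 2 gives > 20000 nM, which is a limit: the limit of > 20000 nM in this assay, at which 1 of the 4 values shown sits. The exchange of (4-methylphenyl)sulfonyl for (4-methylphenyl)carbonyl gives an at least 1.0-fold lower number from compound 2 to compound 4 (0.02 log units; that floor lies within the scatter), so this step shows no difference beyond the scatter.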